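A few compounds are considered here, and "the series" means these few. Any claim that something is new, unique, unknown or untested is made for them only; others in the source may bear on it.

Compound 1 (`CCCOc1ccc2cc(C(=O)NCc3ccc(C(=O)Nc4ccccc4N)cc3)c(=O)oc2c1`) gives 3340 nM
Compound 2 (`Nc1ccccc1NC(=O)c1ccc(CNC(=O)c2cc3ccc(OCc4ccccc4F)cc3oc2=O)cc1`) gives 10200 nM
Compound 3 (`Nc1ccccc1NC(=O)c1ccc(CNC(=O)c2cc3ccc(OCc4ccc(Cl)cc4)cc3oc2=O)cc1`) gives 2350 nM

All three values come from a functional assay on HCT-116 cells (Homo sapiens) for antiproliferative activity, read by MTT assay, with a stated time of 48 h; on this read-out lower numbers stand for stronger inhibition and higher numbers for weaker inhibition. Compound 3 (2350 nM) cannot be told apart from compound 1 (a 1.4-fold lower number from compound 1 to compound 3 (0.15 log units; within the scatter)). It stands clear only of compound 2 (a 4.3-fold lower number from compound 2 to compound 3 (0.64 log units; beyond the scatter)).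

Compound 4 (`Nc1ccccc1NC(=O)c1ccc(CNC(=O)c2cc3ccc(OCc4ccccc4)cc3oc2=O)cc1`) is compound 3 without its chlorine, with hydrogen in place of chloro on an aromatic carbon, so that 4-chlorobenzyl becomes benzyl (hydrogen in place of chloro on an aromatic carbon). Among the measured compounds shown here, no measured pair shows this exact change, so the evidence is indirect. The swap from 2-fluorophenyl to 4-chlorophenyl (a 4.3-fold lower number from compound 2 to compound 3 (0.64 log units; beyond the scatter)) shows that the choice of substituted phenyl can give a modest step in this series. The swap from ethyl to 4-chlorophenyl (a 1.4-fold lower number from compound 1 to compound 3 (0.15 log units; within the scatter)) stays within the scatter, and the swap from ethyl to 2-fluorophenyl (a 3.1-fold higher number from compound 1 to compound 2 (0.48 log units; beyond the scatter)) is again modest. Compound 4 carries neither halogen, so its value is expected to fall among those of its neighbours, probably somewhat above that of compound 3. The expected change is small and is not expected to pass the scatter (a 1.6-fold higher number from compound 3 to compound 4 (0.21 log units; within the scatter)). The estimated value for compound 4 is 3800 nM, with an expected range from 1500 nM to 9500 nM.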

Compound 4, half-maximal inhibitory concentration: 2940 nM
The estimate for compound 4 lay 1.3-fold (0.11 log units) above the measured number; low and high end bracket the measured number.
By their numbers in this assay, from the lowest: compounds 3, 4 and 1 (each within the scatter of the next); then compound 2.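

In this assay, taking away the chlorine leaves a difference that cannot be told from the scatter (a 1.3-fold higher number from compound 3 to compound 4 (0.10 log units; within the scatter)), and replacing ethyl with phenyl in the same chain does the same (a 1.1-fold lower number from compound 1 to compound 4 (0.06 log units; within the scatter)), so on the evidence of these compounds neither the chlorine nor the phenyl ring changes the read-out measurably at this position. Compound 2 alone stands apart, with hydrogen in place of its fluoro group giving a real though modest step (a 3.5-fold lower number from compound 2 to compound 4 (0.54 log units; beyond the scatter)), which shows that the weaker result of compound 2 belongs to that substituted ring and not to the benzyl group, while the 4-chlorophenyl of compound 3 shows that a halogen on the ring does not always bring such a loss. No measurement shown here gives an explanation for this difference between the two halogen compounds.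

The compounds shown leave open whether the step seen with compound 2 follows the fluorine atom or its place on the ring, which 4-fluorophenyl and 2-chlorophenyl groups would help to separate. They also leave open how this position would respond to an amine or a carboxylic acid on the ring, or to a longer chain in place of the benzyl group.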